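The source may report more compounds than this note shows. Statements on the series, on what has been measured and on what is new or still open speak of the compounds shown alone.

Measured compounds:
- compound 1 `O=C(Nc1cc(C(F)(F)F)cc(C(F)(F)F)c1)C(c1ccccc1)c1ccccc1`: 6560 nM
- compound 2 `CN(C(=O)C(c1ccccc1)c1ccccc1)c1cc(C(F)(F)F)cc(C(F)(F)F)c1`: 301 nM
- compound 3 `O=C(NCc1cc(C(F)(F)F)cc(C(F)(F)F)c1)C(c1ccccc1)c1ccccc1`: 526 nM

All three were tested in an assay on CHO cells for displacement of a labelled ligand from Substance-P receptor (Homo sapiens); a higher number here means a weaker inhibitor, a lower number a stronger inhibitor. Among these three, compound 3 holds the second highest number. Its nearest neighbour is compound 2, whose number lies within the usual scatter of that of compound 3, so nothing can be said about an order between them. Compound 1, by contrast, sits clearly higher than compound 3, well beyond the scatter.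

Compound 4 `CN(Cc1cc(C(F)(F)F)cc(C(F)(F)F)c1)C(=O)C(c1ccccc1)c1ccccc1` has not yet been measured in this assay. It differs from compound 3 in one place: methyl in place of hydrogen on an amide-type nitrogen. For the measured compounds named here, one measured step bears directly on this change. The same replacement, carried out on compound 1, gave a 22-fold lower number from compound 1 to compound 2 (1.34 log units; beyond the scatter), a large drop in the number in this assay. Compound 3 already stands far below compound 1, so the same change need not repeat the full size of that step, but its direction is expected to be the same, toward a lower number.

Compound 4 is therefore expected to show a 5.3-fold lower number from compound 3 to compound 4 (0.72 log units; beyond the scatter) in this assay. The estimate for compound 4 is 100 nM, with a range from 30 nM to 400 nM.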

Compound 4, half-maximal inhibitory concentration: 47 nM
Compound 4: the middle estimate sits 2.1-fold (0.33 log units) above what was measured; low and high end bracket the measured number.
By their numbers in this assay, from the lowest: compound 4; then compounds 2 and 3 (each within the scatter of the next); then compound 1.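

In this assay, the replacement of the amide hydrogen by methyl now has a second reading, on a nitrogen whose other neighbours are a carbonyl carbon and a saturated chain carbon, and it gives an 11-fold lower number from compound 3 to compound 4 (1.05 log units; beyond the scatter). The large drop is therefore not confined to the core on which it was first seen, and the two readings agree in direction and, within the scatter, in size: the same change on two cores in this assay, a 22-fold lower number (1.34 log units; beyond the scatter) from compound 1 to compound 2 and an 11-fold lower number (1.05 log units; beyond the scatter) from compound 3 to compound 4, 1.9-fold (0.29 log units) apart, within the scatter of two such steps In both available pairs, the compound with methyl on this nitrogen has the lower number, and neither pair goes against that pattern.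

Hydrogen and methyl are the only groups compared at this position, so it remains open whether an ethyl group, a longer chain or a chain ending in an amine on the same nitrogen would lower the number further, keep it level or raise it. As far as these compounds go, it also remains open whether the step would keep its size on a core other than these two, as two pairs in this assay cannot settle how general it is.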